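Ester in place of tertiary amide on the shared core

A few compounds are considered here, and "the series" means these few. Any claim that something is new, unique, unknown or untested is made for them only; others in the source may bear on it.

Compound 3 `CCn1c(C(=O)N(C)CCC#N)ccc1C(CC)(CC)c1ccc(OCC(=O)C(C)(C)C)c(C)c1` stands highest of the three measured, giving 9800 nM in an assay on HL-60 cells for agonist activity at vitamin D3 receptor (Homo sapiens), read by microscopy, with a stated time of 96 h; a lower number here means that less compound is needed, a higher number that more compound is needed for the effect. Compound 1 `CC[C@@H](C)[C@H](NC(=O)c1ccc(C(CC)(CC)c2ccc(OCC(=O)C(C)(C)C)c(C)c2)n1CC)C(=O)OC` gives 590 nM and compound 2 `CCn1c(C(=O)NCC(OC)OC)ccc1C(CC)(CC)c1ccc(OCC(=O)C(C)(C)C)c(C)c1` gives 130 nM in this assay. Compound 4 `CCOC(=O)CC(C)OC(=O)c1ccc(C(CC)(CC)c2ccc(OCC(=O)C(C)(C)C)c(C)c2)n1CC` carries a group of 9 heavy atoms (6 carbon, 3 oxygen; no ring) in place of a group of 6 heavy atoms (4 carbon, 2 nitrogen; no ring), on a carbonyl carbon. The measured steps that bear on this change are the two made on the same carbonyl carbon: a 17-fold higher number from compound 1 to compound 3 (1.22 log units; beyond the scatter) and a 75-fold higher number from compound 2 to compound 3 (1.88 log units; beyond the scatter), both large. Both show compound 3 set apart from compounds 1 and 2 by what sits on that carbon, so moving away from it is expected to give a lower number in this assay, although the entering group resembles nothing yet measured and the size stays uncertain. The expected step is an 8.2-fold lower number from compound 3 to compound 4 (0.91 log units; beyond the scatter). The estimate for compound 4 is 1200 nM, with a range of 150 nM to 9000 nM.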

Compound 4, half-maximal effective concentration: > 50000 nM
Compound 4 gave a limit, no number; the forecaster's own chance of this, stated with the estimate: 10%; at least 41-fold (1.61 log units) between middle value and limit.
By their numbers in this assay, from the lowest: compound 2; then compound 1; then compound 3. At a limit, above all of these: compound 4.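

In this assay, compound 4 gives a limit and not a number: the limit of > 50000 nM in this assay, at which 1 of the 4 values shown sits. Replacing the tertiary amide with this ester group on the carbonyl carbon gives an at least 5.1-fold higher number from compound 3 to compound 4 (0.70 log units; beyond the scatter), so the number rises further rather than falling, and the gaps to the secondary amides are wider: an at least 380-fold higher number from compound 2 to compound 4 (2.58 log units; beyond the scatter) and an at least 84-fold higher number from compound 1 to compound 4 (1.92 log units; beyond the scatter). Among these four compounds, the two without the amide hydrogen, compound 3 and compound 4, stand highest.

Whether the amide hydrogen itself accounts for this stays open, as does what a carboxylic acid or a simple ethyl ester on this carbonyl carbon would give. From the compounds shown here alone, how far compound 4 lies beyond its limit also stays open.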